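A few compounds are considered here, and "the series" means these few. Any claim that something is new, unique, unknown or untested is made for them only; others in the source may bear on it.

Three compounds measured in an assay on membranes from brain for binding affinity to Lysophosphatidylserine lipase ABHD12 (Mus musculus), read by fluorescence, with a stated time of 20 min (on this read-out higher numbers stand for weaker inhibition and lower numbers for stronger inhibition), set the frame. Compound 1 `FC(F)(F)c1cnc(N2CCC(NC(=S)Nc3cccnc3)CC2)c(Cl)c1` gives 1100 nM, compound 3 `FC(F)(F)c1ccc(N2CCC(NC(=S)Nc3cccnc3)CC2)nc1` gives 1900 nM, and compound 2 `COc1ccc(Oc2ccnc(N3CCC(NC(=S)Nc4cccnc4)CC3)c2)cc1` gives 2900 nM, the highest of the three numbers; compound 3 sits within the scatter of compound 2, while compound 1 lies beyond it. Compound 4 `S=C(Nc1cccnc1)NC1CCN(c2cc(Oc3ccccc3)ccn2)CC1` differs from compound 2 by hydrogen in place of methoxy on an aromatic carbon. Among the measured compounds shown here, the only measured step that resembles this removal of a substituent from an aromatic carbon is a 1.7-fold higher number from compound 1 to compound 3 (0.24 log units; within the scatter), which stayed within the scatter. On that basis the step of a 1.0-fold higher number from compound 2 to compound 4 (0.01 log units; within the scatter) is expected to remain within the scatter, with no clear direction. Compound 4 is therefore estimated at 3000 nM, with a range of 1200 nM to 7500 nM.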

Compound 4, half-maximal inhibitory concentration: 1900 nM
Compound 4: the middle estimate sits 1.6-fold (0.20 log units) above what was measured, and the stated range covers the measured number.
By their numbers in this assay, from the lowest: compounds 1, 3, 4 and 2 (each within the scatter of the next, the first and the last beyond it).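

In this assay, hydrogen in place of methoxy on the 4-methoxyphenoxy group gives a 1.5-fold lower number from compound 2 to compound 4 (0.18 log units; within the scatter). Among the compounds shown here, the earlier step concerned chloro on a different ring, so this is the first reading on this six-membered aromatic ring of carbon only, and at this place, para to a large group, the change stays within the scatter. Nothing available offers an explanation for this result.

From the compounds shown here alone, whether an amine or a carboxylic acid at this place would move the number beyond the scatter remains open.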